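The source may report more compounds than this note shows. Statements on the series, on what has been measured and on what is new or still open speak of the compounds shown alone.

Compound 3, `CCN(CC)CCCOc1ccc(-c2nc3ccc(Oc4cccc(C(F)(F)F)c4)cc3o2)cc1`, is the starting point here. In an assay on isolated protein for inhibition of advanced glycosylation end product-specific receptor (Homo sapiens), read by FRET, with stated times of 30 min and 1 h, tested at 4 uM (a higher number here means more inhibition at the concentration tested (going by the name of the read-out), a lower number less inhibition), compound 3 gives 24.1%, which places it second highest among the three compounds measured. Compound 2, `FC(F)(F)c1ccc(Oc2ccc3nc(-c4ccc(OCCCN5CCCCC5)cc4)oc3c2)cc1`, gives 44.3%, the highest number, and compound 1, `Clc1ccc(Oc2ccc3nc(-c4ccc(OCCCN5CCCCC5)cc4)oc3c2)cc1`, gives 2.2%, the lowest; both gaps to compound 3 lie beyond the scatter. Among the measured compounds shown here, the one measured single-point step, a number 42.1 percentage points higher from compound 1 to compound 2 (beyond the scatter), concerns a change on the aromatic ring rather than the amine, so it does not bear directly on the move to compound 4.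

Compound 4, `FC(F)(F)c1cccc(Oc2ccc3nc(-c4ccc(OCCCN5CCCCC5)cc4)oc3c2)c1`, differs from compound 3 in one place: piperidin-1-yl in place of diethylamino on a saturated chain carbon, three bonds along the chain from an oxygen on an aromatic ring. For the measured compounds named here, no measured pair isolates this exchange of one amine for another at the end of the chain, so there is no step to lean on. Given that, the expected change is a small one, a number 5.9 percentage points higher from compound 3 to compound 4 (within the scatter), not beyond the scatter. Compound 4 is therefore estimated at 30%, within a range of 15% to 48%.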

Compound 4, a percentage reported as inhibition, at one concentration (the size of the read-out at that concentration, not a potency): 42.7%
Compound 4: the middle estimate sits 12.7 percentage points below what was measured; the measured number falls inside the stated range.
By their numbers in this assay, from the lowest: compound 1; then compound 3; then compounds 4 and 2 (each within the scatter of the next).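

Among the compounds shown here, the amine at the end of the chain does matter in this assay with a number 18.6 percentage points higher from compound 3 to compound 4 (beyond the scatter) for piperidin-1-yl in place of diethylamino, the only measured exchange at this place. On an oxygen on an aromatic ring, 3-(trifluoromethyl)phenyl in place of 4-(trifluoromethyl)phenyl gives a number 1.6 percentage points lower from compound 2 to compound 4 (within the scatter) and so shows no difference that can be read, whereas 3-(trifluoromethyl)phenyl in place of 4-chlorophenyl gives a number 40.5 percentage points higher from compound 1 to compound 4 (beyond the scatter) as a clear difference. No measurement available here explains either result.

The compounds shown leave open how a pyrrolidin-1-yl or morpholin-4-yl group at the chain end would compare with piperidin-1-yl, and what a butyl chain would do in place of the propyl chain. They also leave open whether 3-chlorophenyl on that oxygen would read like 4-chlorophenyl or like 3-(trifluoromethyl)phenyl.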